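Methylcarbamoyl for chloro on the benzylamine of compound 2

The source may report more compounds than this note shows. Statements on the series, on what has been measured and on what is new or still open speak of the compounds shown alone.

Measured compounds:
compound 1 `CNc1nc(NCc2ccc(OC(F)(F)F)cc2)cc(-c2ccccn2)n1` — 13 nM
compound 2 `CNc1nc(NCc2ccc(Cl)cc2)cc(-c2ccccn2)n1` — 15 nM
compound 3 `CNc1nc(NCC2CCCCC2)cc(-c2ccccn2)n1` — 11 nM

In a functional assay on HEK293 cells for agonist activity at G-protein coupled receptor 39 (Homo sapiens), read by inositol phosphate accumulation (on this read-out higher numbers stand for an effect only at larger amounts of compound and lower numbers for an effect already at smaller amounts), compound 1 gives 13 nM, compound 2 gives 15 nM and compound 3 gives 11 nM. Compound 2 holds the highest of the three numbers, but its separation from the others is small: the step of a 1.2-fold higher number from compound 1 to compound 2 (0.06 log units; within the scatter) and the step of a 1.4-fold lower number from compound 2 to compound 3 (0.13 log units; within the scatter) both fall within the scatter, so the three compounds cannot be placed in any order of potency on these data.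

Compound 4 `CNC(=O)c1ccc(CNc2cc(-c3ccccn3)nc(NC)n2)cc1` is not yet measured. It differs from compound 2 in one place: methylcarbamoyl in place of chloro on an aromatic carbon. The two measured steps bear on it only loosely. Exchanging trifluoromethoxy for chloro at that position left the number essentially unchanged, and replacing the whole 4-chlorophenyl by cyclohexyl did the same, which suggests that this position tolerates variation. Among the measured compounds shown here, no measured compound, however, carries a hydrogen-bond donor or acceptor there, so the effect of methylcarbamoyl is not directly covered. Compound 4 is therefore expected to stay close to compound 2, with a modest shift toward a higher number allowed for, an expected step of a 1.7-fold higher number from compound 2 to compound 4 (0.22 log units; within the scatter). The estimate for compound 4 in this assay is 25 nM, within a range of 8 nM to 80 nM.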

Compound 4, half-maximal effective concentration: 30 nM
Compound 4: middle estimate off by 1.2-fold (0.08 log units), on the low side; the measured number falls inside the stated range.
By their numbers in this assay, from the lowest: compounds 3, 1, 2 and 4 (each within the scatter of the next, the first and the last beyond it).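

In this assay, among the compounds shown here, methylcarbamoyl is the first group at this position to carry a hydrogen-bond donor and a hydrogen-bond acceptor, and exchanging chloro for it gives a 2.0-fold higher number from compound 2 to compound 4 (0.30 log units; within the scatter), so the tolerance seen with the earlier compounds extends, against chloro, to this larger group of 4 heavy atoms. For the compounds shown here, measured against trifluoromethoxy, the same group gives a 2.3-fold higher number from compound 1 to compound 4 (0.36 log units; beyond the scatter), the only step at this position to pass the scatter, and only a modest one, which makes compound 4 the first sign that a change here can shift the number at all, although that shift is not seen against chloro. No supporting data explain either step.

The compounds shown leave open which part of the new group matters, since neither a dimethylcarbamoyl group, which lacks the amide hydrogen, nor a methyl ketone, which keeps the carbonyl without the nitrogen, appears among them. They also leave open how a carboxylic acid or an aminomethyl group would read at this same place on the ring.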